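A few compounds are considered here, and "the series" means these few. Any claim that something is new, unique, unknown or untested is made for them only; others in the source may bear on it.

Measured in a functional assay on blood (Homo sapiens), with a stated time of 60 min, in the presence of a further agent that is not named here; a lower number here means that less compound is needed, a higher number that more compound is needed for the effect:
- Compound 1 `O=C(Nc1ccccc1O)C1(S(=O)(=O)c2ccc(Oc3ccc(OC(F)(F)F)cc3)cc2)CCC2(CCNCC2)C1`: > 15000 nM (a limit)
- Compound 2 `CN(C)S(=O)(=O)NC(=O)C1(S(=O)(=O)c2ccc(Oc3ccc(OC(F)(F)F)cc3)cc2)CCC2(CCNCC2)C1`: > 15000 nM (a limit)
- Compound 3 `Nc1ccc(-c2ccccc2)cc1NC(=O)C1(S(=O)(=O)c2ccc(Oc3ccc(OC(F)(F)F)cc3)cc2)CCC2(CCNCC2)C1`: <= 400 nM (a limit)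

None of these three results is an exact number. Compound 3 gives <= 400 nM, which is a limit of the assay, so its true position is not known.

Compound 4 `Nc1ccc(-c2cccs2)cc1NC(=O)C1(S(=O)(=O)c2ccc(Oc3ccc(OC(F)(F)F)cc3)cc2)CCC2(CCNCC2)C1` keeps all of compound 3 except one ring: thiophen-2-yl in place of phenyl on an aromatic carbon. Thiophen-2-yl takes the place of phenyl on an aromatic carbon, para to an amino group.

Among the measured compounds shown here, only one measured step exists, a step that the two limits leave unreadable from compound 1 to compound 2. It changes a group on an amide-type nitrogen, not this ring, and so it offers no size to carry over. For the measured compounds named here, no measured step tests the exchange of phenyl for thiophen-2-yl. With nothing pointing either way, no clear change in either direction is expected in this assay. The expected step is a step that the limit leaves unreadable from compound 3 to compound 4. For compound 4 the estimate is 300 nM, with an expected range of 80 nM to 1000 nM.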

Compound 4, half-maximal effective concentration: 900 nM
For compound 4 the middle estimate is 3.0-fold (0.48 log units) below the measured one, and the stated range covers the measured number.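

In this assay, among the compounds shown here, the exchange of phenyl for thiophen-2-yl, para to an amino group, gives the first readable change at this position: an at least 2.2-fold higher number from compound 3 to compound 4 (0.35 log units; beyond the scatter). For the compounds shown here, compound 4 also gives the first exact value here, and it sets the whole 2-amino-5-(thiophen-2-yl)phenyl group on the amide-type nitrogen against two other groups, with an at least 16-fold lower number from compound 2 to compound 4 (1.22 log units; beyond the scatter) and an at least 16-fold lower number from compound 1 to compound 4 (1.22 log units; beyond the scatter). Compound 3 stands at a limit of the assay, so the change at this ring has a minimum size but no exact size: the limit of <= 400 nM in this assay, at which 1 of the 4 values shown sits.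

The compounds shown do not separate the effect of the sulfur atom from that of the smaller ring. Going by these compounds, how a furan-2-yl or pyridin-3-yl ring, or a methyl group without any ring, would behave at this place remains open.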